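Acetyl for Chloroaryl Amide: An Expected Loss of Potency

A few compounds are considered here, and "the series" means these few. Any claim that something is new, unique, unknown or untested is made for them only; others in the source may bear on it.

In a functional assay on NCI-H23 cells (Homo sapiens) for cytotoxicity, read by sulforhodamine B assay, with a stated time of 72 h (a higher number here means a weaker inhibitor of growth, a lower number a stronger inhibitor of growth), compound 2 `O=C(Nc1ccccc1O)C1CCc2ccccc2N1C(=O)c1ccc(Cl)cc1` gives 19200 nM. Compound 1 `CC(=O)N1c2ccccc2CCC1C(=O)Nc1ccccc1O` carries methyl in place of 4-chlorophenyl on a carbonyl carbon; in this assay compound 1 gives 65700 nM, and the step is a 3.4-fold higher number from compound 2 to compound 1 (0.53 log units; beyond the scatter). Compound 3 `O=C(Nc1ccccc1C(F)(F)F)C1CCc2ccccc2N1C(=O)c1ccc(Cl)cc1` is set apart from compound 2 by trifluoromethyl in place of hydroxy on an aromatic carbon, which is also how the core of compound 4 differs from the core of compound 1; in this assay compound 3 gives 307 nM, a step of a 63-fold lower number from compound 2 to compound 3 (1.80 log units; beyond the scatter), and it holds the lowest number of the three. Compound 4 `CC(=O)N1c2ccccc2CCC1C(=O)Nc1ccccc1C(F)(F)F` has not yet been measured. It carries methyl in place of 4-chlorophenyl on a carbonyl carbon, the same change that separates compound 2 from compound 1, at the same place. Resting on a 3.4-fold higher number from compound 2 to compound 1 (0.53 log units; beyond the scatter), the expected step is a 3.3-fold higher number from compound 3 to compound 4 (0.51 log units; beyond the scatter). Compound 4 is therefore estimated at 1000 nM, expected to fall between 350 nM and 3500 nM.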

Compound 4, concentration for 50% growth inhibition: > 80000 nM
Compound 4 was reported as a limit; the forecaster's own chance of this, stated with the estimate: 3%; at least 80-fold (1.90 log units) between middle value and limit.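

In this assay compound 4 stands at > 80000 nM, which is a limit of the assay and not a number. Methyl in place of 4-chlorophenyl on the carbonyl carbon gives an at least 260-fold higher number from compound 3 to compound 4 (2.41 log units; beyond the scatter), so this change did not carry over in size from one core to the other: the same change on two cores in this assay, a 3.4-fold higher number (0.53 log units; beyond the scatter) from compound 2 to compound 1 and an at least 260-fold higher number (2.41 log units; beyond the scatter) from compound 3 to compound 4, at least 76-fold (1.88 log units) apart, beyond the scatter of two such steps That step and an at least 1.2-fold higher number from compound 1 to compound 4 (0.08 log units; that floor lies within the scatter) are only floors, so the pairs show that neither change transfers unaltered on these cores, but not how far compound 4 truly lies from compound 1 or compound 3: the same change on two cores in this assay, a 63-fold lower number (1.80 log units; beyond the scatter) from compound 2 to compound 3 and an at least 1.2-fold higher number (0.08 log units; that floor lies within the scatter) from compound 1 to compound 4, at least 76-fold (1.88 log units) apart, beyond the scatter of two such steps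

The compounds shown leave open whether an ethyl, an unsubstituted phenyl or a longer chain on the carbonyl carbon would follow compound 3 or compound 4. They also leave open how a nitrile would behave in place of trifluoromethyl on the aromatic carbon.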